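The source may report more compounds than this note shows. Statements on the series, on what has been measured and on what is new or still open speak of the compounds shown alone.

Compounds measured so far:
compound 1, `Clc1ccccc1/C=N/c1sc2c(c1-c1nc3ccccc3s1)CCC2`: 180 ug/mL
compound 2, `Clc1ccc(/C=N/c2sc3c(c2-c2nc4ccccc4s2)CCC3)c(Cl)c1`: 310 ug/mL
compound 3, `Clc1ccc(/C=N/c2sc3c(c2-c2nc4ccccc4s2)CCCC3)cc1`: 397 ug/mL

Of the compounds shown here, three have been tested in an ADME assay on HepG2 cells (Homo sapiens) for cytotoxicity, read by MTT assay, with a stated time of 72 h; on this read-out higher numbers stand for lower toxicity in this test and lower numbers for higher toxicity in this test. Compound 1 gives 180 ug/mL in this assay, compound 2 gives 310 ug/mL, and compound 3 gives 397 ug/mL. Compound 2 differs from compound 1 by chloro in place of hydrogen on an aromatic carbon, and that step made a 1.7-fold higher number from compound 1 to compound 2 (0.24 log units; within the scatter). The difference between the cores of compound 1 and compound 3 is not broken down here.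

Compound 4, `Clc1ccc(/C=N/c2sc3c(c2-c2nc4ccccc4s2)CCCC3)c(Cl)c1`, has not yet been tested. It differs from compound 3 by chloro in place of hydrogen on an aromatic carbon. This is the same kind of change as from compound 1 to compound 2, but not the same one: there the new chloro sat para to a large group, here it sits ortho to a large group. Because the earlier step was a 1.7-fold higher number from compound 1 to compound 2 (0.24 log units; within the scatter), the step of a 1.2-fold higher number from compound 3 to compound 4 (0.08 log units; within the scatter) is expected to be of similar size. Compound 4 is therefore estimated at 480 ug/mL, between 260 ug/mL and 850 ug/mL.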

Compound 4, half-maximal cytotoxic concentration: 384 ug/mL
Beside the measured number, compound 4's estimate is 1.3-fold (0.10 log units) above it, within the range that was stated.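

In this assay, chloro in place of hydrogen gives a 1.0-fold lower number from compound 3 to compound 4 (0.01 log units; within the scatter), a step that cannot be told apart from the usual spread of repeated measurements. Set beside the same change on the other core, the two steps do not differ by more than that spread allows: the same change on two cores in this assay, a 1.7-fold higher number (0.24 log units; within the scatter) from compound 1 to compound 2 and a 1.0-fold lower number (0.01 log units; within the scatter) from compound 3 to compound 4, 1.8-fold (0.25 log units) apart, within the scatter of two such steps. For the compounds shown here, this is consistent with the change behaving alike on both cores, but with only two pairs, each within the scatter, it does not show that chloro has a real effect on either core or that the result would hold on other cores.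

Every aromatic ring substituent shown here is a chloro, so it remains open how a methoxy group, a nitro group or an amine would read in its place.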